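The compounds below may be only part of what the source reports. "The series", "measured", "known", "first", "only" and "open" are said of these compounds alone.

Working notes on the series

Three amides on the shared core have been measured in a functional assay on HeLa cells (Homo sapiens) for cytotoxicity, read by MTT assay, with a stated time of 24 h; a higher number here means a weaker inhibitor, a lower number a stronger inhibitor. Compound 1 `CCCNC(=O)Cn1nc(N)c2c(C(F)(F)F)cc(-c3ccccc3)nc21` gives 15900 nM and stands lowest of the three numbers; its nearest neighbour is compound 3 `Nc1nn(CC(=O)NCc2ccccc2)c2nc(-c3ccccc3)cc(C(F)(F)F)c12`, which gives 17100 nM, and the furthest is compound 2 `NNC(=O)Cn1nc(N)c2c(C(F)(F)F)cc(-c3ccccc3)nc21`, which gives 48400 nM. Both steps from compound 1 touch the same place: a 3.0-fold higher number from compound 1 to compound 2 (0.48 log units; beyond the scatter), while a 1.1-fold higher number from compound 1 to compound 3 (0.03 log units; within the scatter). Among the measured compounds shown here, the reverse comparison, a 2.8-fold lower number from compound 2 to compound 3 (0.45 log units; beyond the scatter), is the only other step beyond the scatter.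

Compound 4 `Nc1nn(CC(=O)N2CCOCC2)c2nc(-c3ccccc3)cc(C(F)(F)F)c12` is the next member, not yet measured. Against compound 1 the change is morpholin-4-yl in place of propylamino on a carbonyl carbon. The two measured steps that bear on it, the step from compound 1 to compound 2 and the step from compound 1 to compound 3, both alter the group on the amide nitrogen and together span from within the scatter to a modest rise. For the measured compounds named here, no measured compound lacks the amide hydrogen, so the data give no direct precedent. The expectation for compound 4 is therefore a number near compound 1, with the step of a 1.4-fold higher number from compound 1 to compound 4 (0.14 log units; within the scatter), anything from none to a modest rise. The estimate for compound 4 is 22000 nM, with a range from 9000 nM to 55000 nM.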

Compound 4, half-maximal inhibitory concentration: 6600 nM
The estimate for compound 4 lay 3.3-fold (0.52 log units) above the measured number; measured number outside the range, below it.
By their numbers in this assay, from the lowest: compound 4; then compounds 1 and 3 (each within the scatter of the next); then compound 2.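

In this assay, among the compounds shown here, the group on this carbonyl carbon can also lower the number: the earlier steps away from compound 1 showed either no shift beyond the scatter or a rise, whereas morpholin-4-yl gives (a 2.4-fold lower number from compound 1 to compound 4 (0.38 log units; beyond the scatter)) and, against the benzylamino amide, (a 2.6-fold lower number from compound 3 to compound 4 (0.41 log units; beyond the scatter)). For the compounds shown here, the same change gives the largest step (a 7.3-fold lower number from compound 2 to compound 4 (0.87 log units; beyond the scatter)), and with all three of its steps beyond the scatter, compound 4 is the strongest of the four compounds in this assay, the only one here with a ring bonded directly through nitrogen to the carbonyl carbon and without the amide hydrogen. No measurement available here accounts for this shift.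

The one change brings in the ring and its oxygen and removes the amide hydrogen all at once, so the compounds shown cannot say which of these goes with the lower number; a piperidin-1-yl group would keep the ring without the oxygen, and a dipropylamino group would lose the amide hydrogen without any ring. As far as these compounds go, whether a piperazin-1-yl group at the same carbonyl carbon would match morpholin-4-yl also stays open.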